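A few compounds are considered here, and "the series" means these few. Any claim that something is new, unique, unknown or untested is made for them only; others in the source may bear on it.

Compound 1 `C[C@@H](C(=O)N[C@H](C#N)CC(N)=O)N(Cc1ccc(-c2cccc(C(F)(F)F)c2)cc1)S(C)(=O)=O` gives 601 nM in an assay on isolated protein for inhibition of legumain (Homo sapiens), with stated times of 2 min and 60 min; on this read-out lower numbers stand for stronger inhibition and higher numbers for weaker inhibition.
Compound 2 `C[C@H](C(=O)N[C@H](C#N)CC(N)=O)N(Cc1ccc(-c2cccc(C(F)(F)F)c2)cc1)S(C)(=O)=O` gives > 10000 nM in this assay, a limit of the assay and not a number.
Compound 3 `C[C@@H](C(=O)N[C@H](C#N)CC(N)=O)N(Cc1ccc(-c2cccc(F)c2)cc1)S(=O)(=O)c1ccccc1` gives > 10000 nM in this assay, again a limit.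

Compound 2 therefore stands at the upper edge of what is shown, sharing (the limit of > 10000 nM in this assay, at which 2 of the 3 values shown sit). Among the measured compounds shown here, the one measured step that reaches it is an at least 16-fold higher number from compound 1 to compound 2 (1.22 log units; beyond the scatter), a large loss, which rests on (the fact that compounds 1 and 2 differ only in the configuration as drawn). Compound 4 `C[C@H](C(=O)N[C@H](C#N)CC(N)=O)N(Cc1ccc(-c2ccc(F)cc2)cc1)S(C)(=O)=O` keeps the configuration of compound 2 and differs by 4-fluorophenyl in place of 3-(trifluoromethyl)phenyl on an aromatic carbon. For the measured compounds named here, no measured step covers this aryl swap alone; compound 3 changes more than one place at once. With compound 2 already at the limit, the step that the limit leaves unreadable from compound 2 to compound 4 is expected to show no gain beyond the scatter, and compound 4 is estimated at 15000 nM, within 5000 nM to 50000 nM.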

Compound 4, half-maximal inhibitory concentration: > 10000 nM
Compound 4 ended at the assay's limit; the forecaster's own chance of this, stated with the estimate: 85%; the middle value does not contradict the limit.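

Compound 2 and compound 4 both end at a limit of this assay, not at a number, so the step between them cannot be read. The compounds shown leave open how 4-fluorophenyl would fare in the configuration of compound 1.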